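This account rests on a few compounds, and the source may have more. Where it says the series, first, only, none or still open, it means among the compounds named here.

In a functional assay on L5178Y cells (Mus musculus) for inhibition, read by MTT assay, with a stated time of 24 h (on this read-out higher numbers stand for weaker inhibition and lower numbers for stronger inhibition), two compounds sharing one core have been measured. Compound 1 `COc1cc(O)c2c(c1)O[C@H](c1ccc(O)cc1)C/C2=N\Nc1ccccc1` gives >= 11300 nM, which is a limit of the assay and not a number. Compound 2 `COc1cc(O)c2c(c1)O[C@H](c1ccc(O)cc1)C/C2=N\NC(=O)c1ccc(C(F)(F)F)cc1` gives >= 11300 nM, which is likewise a limit and not a number. Within the data shown here, the data so far therefore show only (the limit of >= 11300 nM in this assay, at which 2 of the 2 values shown sit), and no measured step gives a size of change to build on.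

The next compound keeps the core of compound 2 and alters the group on the carbonyl carbon. Compound 3 `COc1cc(O)c2c(c1)O[C@H](c1ccc(O)cc1)C/C2=N\NC(=O)c1ccco1` carries furan-2-yl in place of 4-(trifluoromethyl)phenyl on a carbonyl carbon.

Among the measured compounds shown here, with no step to guide the estimate, no change beyond the usual scatter is expected in this assay, in either direction, and compound 3 may well report only a limit too. This expectation rests on compound 2, whose limit is >= 11300 nM. The expected change is a step that the limit leaves unreadable from compound 2 to compound 3. For compound 3 the estimated value is 14000 nM, with an expected range from 6000 nM to 35000 nM.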

Compound 3, half-maximal inhibitory concentration: >= 11300 nM
Compound 3 gave a limit, no number (the forecaster's own chance of this, stated with the estimate: 65%); the middle value is on the limit's open side.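

Compound 3, like compound 1 and compound 2, gives a limit and not a number in this assay, so neither step to compound 3 can be read: the limit of >= 11300 nM in this assay, at which 3 of the 3 values shown sit. The compounds shown leave open how strongly any of the three inhibits and whether any change on the shared core would give a measurable value.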